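Adding a methoxy to compound 2: expected binding

The compounds below may be only part of what the source reports. "The series", "measured", "known", "first", "only" and "open" are said of these compounds alone.

Among the compounds with values here, compound 2 `Clc1ccc(C2=CC3CNCC(C2)C3)cn1` stands lowest of the three numbers so far in an in vitro assay on SH-SY5Y cells for displacement of a labelled ligand from Neuronal acetylcholine receptor; alpha3/beta4 (Homo sapiens); a lower number here means a stronger inhibitor, a higher number a weaker inhibitor: compound 2 gives 6.2 nM. Nearest to it is compound 3 `Fc1ccc(C2=CC3CNCC(C2)C3)cn1`, which in this assay gives 28 nM; the step of a 4.5-fold higher number from compound 2 to compound 3 (0.65 log units; beyond the scatter) is the only single-point step in the set. Furthest away is compound 1 `COc1cc(C2=CC3CC(C2)CN(C)C3)cnc1Cl`, which in this assay gives 1430 nM; compound 1 differs from compound 2 in two places, a methoxy on the ring and a methyl on the amine, so its number cannot be split between the two changes.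

Compound 4 `COc1cc(C2=CC3CNCC(C2)C3)cnc1Cl` is not yet measured. It differs from compound 2 in one place: methoxy in place of hydrogen on an aromatic carbon. Within the data shown here, no measured step isolates this change. The step from compound 2 to compound 3 exchanges one halogen for another and does not bear on a methoxy. Compound 1 carries the same methoxy and chloro as compound 4 plus the methyl on the amine; its gap to compound 2 is a ceiling for what the methoxy alone might cost, but how much of that gap belongs to the methyl is not known here. The expectation is therefore a moderate rise, well short of the gap to compound 1: for compound 4 in this assay the estimate is 60 nM, ranging from 10 nM to 400 nM, an expected step of a 9.7-fold higher number from compound 2 to compound 4 (0.99 log units; beyond the scatter).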

Compound 4, inhibition constant: 7 nM
The estimate for compound 4 lay 8.6-fold (0.93 log units) above the measured number; measured number outside the range, below it.
By their numbers in this assay, from the lowest: compounds 2 and 4 (each within the scatter of the next); then compound 3; then compound 1.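

Methoxy in place of hydrogen on this aromatic carbon, ortho to a chloro group and two atoms from the ring nitrogen, gives in this assay a 1.1-fold higher number from compound 2 to compound 4 (0.05 log units; within the scatter), so the position accepts this group with no measurable loss of binding. The large gap seen for compound 1 can now be placed: hydrogen in place of methyl on the amine nitrogen in the ring gives a 200-fold lower number from compound 1 to compound 4 (2.31 log units; beyond the scatter), and with methoxy and chloro present on both compounds, that single change accounts for the whole step. Nothing measured here gives a reason for either step.

Whether the methyl on the amine weighs as heavily without the methoxy remains open, as the methyl appears only in compound 1, alongside the methoxy, and an ethyl on that nitrogen is not among the compounds shown. Going by these compounds, it is equally open whether the same aromatic carbon would accept an ethoxy, a hydroxy or an amine as it accepts the methoxy, and whether the methoxy would be accepted with fluoro in place of chloro, as in compound 3.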